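The source may report more compounds than this note shows. Statements on the series, on what has been measured and on what is new or still open speak of the compounds shown alone.

Measured compounds in a functional assay on A549 cells (Homo sapiens) for cytotoxicity, with a stated time of 48 h; a higher number here means a weaker inhibitor, a lower number a stronger inhibitor:

Compound 1, `CCC(=O)Oc1ccc2oc(/C=C/[S+](C)[O-])cc(=O)c2c1`, gives 2400 nM.
Compound 2, `COc1ccc2c(=O)cc(/C=C/[S+](C)[O-])oc2c1`, gives 2200 nM.
Compound 3, `COc1cccc2oc(/C=C/[S+](C)[O-])cc(=O)c12`, gives 3800 nM.

The three compounds share a core and differ in the group placed on it and in where that group sits. In this assay compound 1 stands second of the three numbers, yet its gaps to both neighbours lie within the usual scatter of repeated measurements: compound 2 sits nearest, and compound 3, the furthest of the two, still falls inside that scatter. For the measured compounds named here, no pair among the measured compounds differs in a single place, so the data give no calibrated single step to lean on.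

Compound 4, `CCCCC(=O)Oc1ccc2oc(/C=C/[S+](C)[O-])cc(=O)c2c1`, is the unmeasured compound. Its difference from compound 1 is ethyl in place of hydrogen on a saturated chain carbon, two bonds along the chain from a carbonyl carbon; cut one bond further out, the same change reads as propanoyl to butylcarbonyl on the ester.

Going by the values given here, with no measured step of this kind, the expectation rests on the small spread among compounds 1, 2 and 3. The step of a 1.2-fold lower number from compound 1 to compound 4 (0.08 log units; within the scatter) is expected to be small and within the scatter, with no firm direction. Compound 4 is therefore estimated at 2000 nM in this assay, with a range from 800 nM to 5000 nM.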

Compound 4, half-maximal inhibitory concentration: 2400 nM
For compound 4 the middle estimate is 1.2-fold (0.08 log units) below the measured one; the measured number falls inside the stated range.
By their numbers in this assay, from the lowest: compounds 2, 1, 4 and 3 (each within the scatter of the next).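

Ethyl in place of hydrogen on a saturated chain carbon, two bonds along the chain from a carbonyl carbon, gives the first single-place step in this set: in this assay it shows no change at the digits printed from compound 1 to compound 4 (within the scatter). The earlier compounds shown here, none of which differed from another in one place, could not show how this assay responds to a change at this position; here, lengthening the ester from propanoyl to butylcarbonyl leaves no readable shift in the cytotoxicity number. Nothing among the available data bears on why the number holds across this change.

The compounds shown leave open whether the same flat response would persist with a still longer chain such as hexanoyl, a branched acyl group such as pivaloyl, or a chain ending in an amine or a carboxylic acid. They also leave open whether an amide in place of the ester would keep the number, and whether the ethyl step would read the same with the ester placed elsewhere on the shared core.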